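Iodine for fluorine on the phenoxy ring of compound 3

The source may report more compounds than this note shows. Statements on the series, on what has been measured and on what is new or still open speak of the compounds shown alone.

Compound 1 `Cc1nnsc1CO/N=C/c1c(C)nn(C)c1Oc1cccc(F)c1`: > 50000 nM in a functional assay on PANC-1 cells (Homo sapiens) for inhibition, read by MTT assay, with a stated time of 48 h (a higher number here means a weaker inhibitor, a lower number a stronger inhibitor), a limit of the assay rather than a number.
Compound 2 `Cc1nnsc1CO/N=C/c1c(C)nn(C)c1Oc1cccc(C(F)(F)F)c1`: > 50000 nM in this assay, again only a limit.
Compound 3 `Cc1nnsc1CO/N=C/c1c(C)nn(C)c1Oc1ccc(F)cc1`: > 50000 nM in this assay, again only a limit.

Compound 3 therefore stands nowhere in particular on these numbers: it sits at the limit of > 50000 nM in this assay, at which 3 of the 3 values shown sit, and so do the other two compounds. The step that the two limits leave unreadable from compound 1 to compound 2 and the step that the two limits leave unreadable from compound 1 to compound 3 are both unreadable for that reason, so no measured step tells how much any change on the phenoxy ring moves the result.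

Compound 4 `Cc1nnsc1CO/N=C/c1c(C)nn(C)c1Oc1ccc(I)cc1` differs from compound 3 in one place: iodo in place of fluoro on an aromatic carbon of a six-membered aromatic ring of carbon only, para to a large group.

Among the compounds with values here, no measured step bears on this change in a readable way. What is known is that three variations on this ring all left the result at the limit, so compound 4 is expected to behave the same: the expected step that the limit leaves unreadable from compound 3 to compound 4 is none beyond the scatter. Compound 4 is estimated at 60000 nM, with a range from 20000 nM to 200000 nM, most likely reported again only as a limit.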

Compound 4, half-maximal inhibitory concentration: > 50000 nM
Compound 4: no number, only a limit; the forecaster's own chance of this, stated with the estimate: 80%; the middle value is on the limit's open side.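

Compound 4 gives > 50000 nM in this assay, which is a limit and not a number. The steps from compound 3 and compound 1 to compound 4 therefore cannot be read, and all the compounds shown share one position: the limit of > 50000 nM in this assay, at which 4 of the 4 values shown sit.

The compounds shown leave open whether any change on the phenoxy ring moves the result at all.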